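A few compounds are considered here, and "the series" means these few. Any claim that something is new, unique, unknown or untested is made for them only; others in the source may bear on it.

Among the measured compounds shown here, compound 2 `CCCCN1CCc2nc(C#Cc3ccccc3)sc2C1` holds the higher of the two numbers measured so far in an assay on HEK293 cells for positive allosteric modulation of metabotropic glutamate receptor 5 (Homo sapiens), read by FLIPR, with a stated time of 1 h (on this read-out lower numbers stand for an effect already at smaller amounts and higher numbers for an effect only at larger amounts of compound), where compound 2 gives 110 nM. Its nearest neighbour, compound 1 `CN1CCc2nc(C#Cc3ccccc3)sc2C1`, gives 34 nM. That difference, a 3.2-fold higher number from compound 1 to compound 2 (0.51 log units; beyond the scatter), came from lengthening a chain at the same place. Compound 3 `CC(C)CN1CCc2nc(C#Cc3ccccc3)sc2C1` differs from compound 2 by isopropyl in place of propyl on a saturated chain carbon bound to an amine nitrogen in a ring. For the measured compounds named here, the single measured step concerns chain length rather than a branched arrangement of the same atoms, so it bears only loosely on this change, and no step addresses branching directly. Compound 3 is therefore expected to show a step of no change at the digits printed from compound 2 to compound 3 (within the scatter) that stays within the scatter. The estimate for compound 3 is 110 nM, between 40 nM and 330 nM.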

Compound 3, half-maximal effective concentration: > 10000 nM
Compound 3 ended at the assay's limit (the forecaster's own chance of this, stated with the estimate: 3%); middle value at least 90-fold (1.95 log units) away from the limit.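

At this position, how the atoms are joined matters and not just how many there are: butyl and isobutyl hold the same atoms, yet the change gives an at least 90-fold higher number from compound 2 to compound 3 (1.95 log units; beyond the scatter). That step and an at least 290-fold higher number from compound 1 to compound 3 (2.46 log units; beyond the scatter) both go much further than the earlier 3.2-fold higher number from compound 1 to compound 2 (0.51 log units; beyond the scatter). Compound 3 stands at a limit of the assay, not at a number: the limit of > 10000 nM in this assay, at which 1 of the 3 values shown sits.

As far as these compounds go, whether a longer straight chain such as pentyl, or a cyclopropylmethyl group, keeps the effect stays open.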